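The source may hold more compounds than are shown below. What is called first, only, known or untested is meant among the compounds shown, and "the series" means these compounds.

Working notes on the thiocarbamate series.

Of the compounds shown here, two have numbers so far. Compound 1 `Cc1ccc(NC(=S)OCCNC(=O)C(C)(C)Oc2ccc(Cl)cc2)cc1` carries a chloro-substituted aryloxy amide on the chain; compound 2 `O=C(NCCOC(=S)Nc1ccccc1)c1cccnc1` carries a pyridine amide instead. In an ADME assay for pharmacokinetics, in phosphate buffer, tested at 60 uM (on this read-out higher numbers stand for a longer-lived compound and lower numbers for a shorter-lived compound), compound 1 gives 0.0167 h, and in the same assay compound 2 gives 0.02 h. The two numbers lie within the scatter of each other, so on the numbers shown compound 2 stands together with compound 1 and nothing separates them: both are very short-lived in this assay.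

The next compound, compound 3 `COc1ccc(NC(=S)OCCNC(=O)c2cccnc2)cc1`, keeps the whole of compound 2 and differs from it in one place: methoxy in place of hydrogen on an aromatic carbon.

Among the compounds with values here, no measured pair covers a change of this kind, so there is no step to lean on. With both measured numbers sitting close together and the change confined to a single small group on the aromatic ring, the expectation is no step beyond the scatter in this assay, the expected step being no change at the digits printed from compound 2 to compound 3 (within the scatter). Compound 3 is therefore estimated at 0.02 h, with a range from 0.01 h to 0.04 h.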

Compound 3, half-life: 0.0133 h
Estimate against measurement, compound 3: 1.5-fold (0.18 log units) above; low and high end bracket the measured number.
By their numbers in this assay, from the lowest: compounds 3, 1 and 2 (each within the scatter of the next).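

In this assay, within the data shown here, the step of a 1.5-fold lower number from compound 2 to compound 3 (0.18 log units; within the scatter) gives the first reading of this change: methoxy in place of hydrogen on an aromatic carbon, para to a large group, stays within the scatter. On this single pair, the position takes the added oxygen and carbon with no step that can be told apart from repeat measurements, and compound 3 remains as short-lived as compound 2 on the numbers shown. Nothing available here speaks to what sets the half-life in this pair.

The compounds shown leave open whether a different group at the same place, such as a dimethylamino group, a carboxylic acid or a trifluoromethyl group, would give a step beyond the scatter. They also leave open whether any change on this aromatic ring can lengthen the half-life at all, or whether a change elsewhere in the shared core, such as a longer chain, would be needed to do so.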